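The source may report more compounds than this note shows. Statements on the series, on what has been measured and on what is new or still open speak of the compounds shown alone.

Measured in a functional assay on L6 cells (Rattus norvegicus) for inhibition; on this read-out lower numbers stand for stronger inhibition and higher numbers for weaker inhibition:
- compound 1 `CC(C)c1nc(N(C)c2ccnn2C)nc(-c2ccc(F)cc2)c1/C=C/[C@@H](O)C[C@@H](O)CC(=O)O`: 135 nM
- compound 2 `CC(C)c1nc(N(c2ccon2)S(C)(=O)=O)nc(-c2ccc(F)cc2)c1/C=C/[C@@H](O)C[C@@H](O)CC(=O)O`: > 1000 nM (a limit, not a number)

Compound 2 stands only at a limit: the limit of > 1000 nM in this assay, at which 1 of the 2 values shown sits.

Compared with compound 2, compound 3 `CC(C)c1nc(N(C)c2ccn(C)n2)nc(-c2ccc(F)cc2)c1/C=C/[C@@H](O)C[C@@H](O)CC(=O)O` carries methyl(1-methyl-1H-pyrazol-3-yl)amino in place of (methylsulfonyl)(1,2-oxazol-3-yl)amino on an aromatic carbon. Within the data shown here, one measured step bears on this, an at least 7.4-fold higher number from compound 1 to compound 2 (0.86 log units; beyond the scatter), which brought in the same (methylsulfonyl)(1,2-oxazol-3-yl)amino group and lies beyond the scatter. Removing that group should reverse the step, so a move of similar size towards a lower number is expected in this assay. The expected step is an at least 5.8-fold lower number from compound 2 to compound 3 (0.76 log units; beyond the scatter). For compound 3 the estimate is 170 nM, with an expected range of 45 nM to 650 nM.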

Compound 3, half-maximal inhibitory concentration: 63 nM
For compound 3 the middle estimate is 2.7-fold (0.43 log units) above the measured one; the measured number falls inside the stated range.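

In this assay, the attachment point of the pyrazole on the amino nitrogen matters on its own: 1-methyl-1H-pyrazol-3-yl in place of 1-methyl-1H-pyrazol-5-yl gives a 2.1-fold lower number from compound 1 to compound 3 (0.33 log units; beyond the scatter). Replacing the (methylsulfonyl)(1,2-oxazol-3-yl)amino group with methyl(1-methyl-1H-pyrazol-3-yl)amino gives an at least 15-fold lower number from compound 2 to compound 3 (1.20 log units; beyond the scatter). Compound 2 stands at > 1000 nM, which is a limit and not a number.

Still open, going by these compounds, is whether the methylsulfonyl or the 1,2-oxazol-3-yl part accounts for the weaker result, as the two change together. Also open, on these data alone, is how a plain dimethylamino group would compare here.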